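The source may report more compounds than this note shows. Statements on the series, on what has been measured and on what is new or still open speak of the compounds shown alone.

For the measured compounds named here, compound 1 `CCc1nn(-c2ccccc2C)c2c1[C@@H](c1ccc(Oc3ccccc3)cc1)S[C@@H](C)C(=O)N2` is the only member of this small set with a number: in an assay on isolated protein for agonist activity at Bile acid receptor (Homo sapiens), read by AlphaScreen, with a stated time of 30 min (on this read-out higher numbers stand for an effect only at larger amounts of compound and lower numbers for an effect already at smaller amounts), compound 1 gives 2000 nM. Compound 2 `Cc1ccccc1-n1nc(C)c2c1NC(=O)[C@H](C)S[C@H]2c1ccc(Oc2ccccc2)cc1` reaches only the limit of the assay, > 150000 nM. Compound 3 `Cc1ccccc1-n1nc(C)c2c1NC(=O)[C@@H](C)S[C@H]2c1ccc(Oc2ccccc2)cc1` likewise stops at the limit, > 150000 nM. Between those two the step that the two limits leave unreadable from compound 2 to compound 3 cannot be read, because of the limit of > 150000 nM in this assay, at which 2 of the 3 values shown sit, and because of the fact that compounds 2 and 3 differ only in the configuration as drawn. Compound 4 `Cc1ccccc1-n1ncc2c1NC(=O)[C@H](C)S[C@@H]2c1ccc(Oc2ccccc2)cc1` differs from compound 1 by hydrogen in place of ethyl on an aromatic carbon. Going by the values given here, no measured step covers this change, so the expectation rests on compound 1 alone. Compound 4 is therefore estimated at 10000 nM, between 2000 nM and 80000 nM, which would mean a step of a 5.0-fold higher number from compound 1 to compound 4 (0.70 log units; beyond the scatter) expected toward an effect only at larger amounts.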

Compound 4, half-maximal effective concentration: > 150000 nM
Compound 4 was reported as a limit; the forecaster's own chance of this, stated with the estimate: 25%; middle value at least 15-fold (1.17 log units) from the limit.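

For the compounds shown here, replacing ethyl with hydrogen on this aromatic carbon gives the first readable step in the set, and it is large: an at least 75-fold higher number from compound 1 to compound 4 (1.87 log units; beyond the scatter). The value of compound 4, > 150000 nM, is a limit of the assay. This shows that activity in this assay depends strongly on what sits at this position, although the full size of the step stays unread because of this: the limit of > 150000 nM in this assay, at which 3 of the 4 values shown sit.

On these data alone, whether a longer chain such as propyl, or an amine, on this carbon would give a lower number than compound 1 remains open. The step between the two other compounds at the limit cannot be read.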